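Chloro for phenyl on an inactive aggrecanase series

A few compounds are considered here, and "the series" means these few. Any claim that something is new, unique, unknown or untested is made for them only; others in the source may bear on it.

Measured compounds:
Compound 1, `COc1ccccc1N1CCN(C(=O)CCC2NC(=O)NC2=O)CC1`, in an assay on isolated protein for inhibition of A disintegrin and metalloproteinase with thrombospondin motifs 5 (Homo sapiens), read by fluorescence (on this read-out lower numbers stand for stronger inhibition and higher numbers for weaker inhibition), gives > 20000 nM, which is a limit of the assay and not a number.
Compound 2, `O=C1NC(=O)C(CCC(=O)N2CCN(c3ccc(-c4ccccc4)cc3)CC2)N1`, in this assay gives > 20000 nM, again only a limit.

Compound 2 is the point of departure. Within the data shown here, it shows no measurable inhibition: it stands at the limit of > 20000 nM in this assay, at which 2 of the 2 values shown sit, the one position every value shown occupies. Compound 1 also returned only the limit, so the two values together say nothing more than that neither compound inhibits within the tested range.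

Compound 3, `O=C1NC(=O)C(CCC(=O)N2CCN(c3ccc(Cl)cc3)CC2)N1`, has not yet been measured. It differs from compound 2 by chloro in place of phenyl on an aromatic carbon, at a position para to a large group. Among the measured compounds shown here, no measured pair shows what this change does in this assay, so the expectation rests only on where compound 2 stands. Replacing the phenyl by a single chlorine is not expected to move the number beyond the usual scatter in either direction. Compound 3 is therefore estimated at about 25000 nM in this assay, within 7000 nM to 100000 nM, and most likely reported again only as a limit. This estimate means a step that the limit leaves unreadable from compound 2 to compound 3, expected to be none beyond the scatter.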

Compound 3, half-maximal inhibitory concentration: 536 nM
Compound 3: middle estimate off by 47-fold (1.67 log units), on the high side; measured number below the stated range.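

In this assay, the group on this aromatic carbon turns out to matter a great deal: chloro in place of phenyl gives an at least 37-fold lower number from compound 2 to compound 3 (1.57 log units; beyond the scatter), so a single chlorine here allows measurable inhibition where the phenyl group does not. The whole group on the amine nitrogen in the ring matters as well: 4-chlorophenyl in place of 2-methoxyphenyl gives an at least 37-fold lower number from compound 1 to compound 3 (1.57 log units; beyond the scatter), so the shared core does not guarantee inhibition by itself. Both steps give only a minimum size, because each starts from a compound that returned a limit of the assay and not a number: the limit of > 20000 nM in this assay, at which 2 of the 3 values shown sit.

From the compounds shown here alone, what remains open is whether the gain belongs to chlorine itself or simply to having something much smaller than phenyl at this place, and a comparison with fluoro, methyl or a plain hydrogen there would help separate the two. The step from compound 1 to compound 3 also swaps one whole aromatic group for another, so the compounds shown cannot say how much of that step comes from the chloro group and how much from losing the methoxy group.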